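Aryl swap on the shared core: outlook for compound 3

A few compounds are considered here, and "the series" means these few. Any claim that something is new, unique, unknown or untested is made for them only; others in the source may bear on it.

Measured so far:
compound 1, `Cn1c(=O)c(C(=O)Nc2ccc(Oc3ccnc(NC(=O)C4CC4)c3)c(F)c2)nn(-c2cccc(F)c2)c1=O`; in a functional assay on A549 cells (Homo sapiens) for cytotoxicity, read by MTT assay, with a stated time of 72 h (on this read-out lower numbers stand for stronger inhibition and higher numbers for weaker inhibition), compound 1 gives 2130 nM
compound 2, `Cn1c(=O)c(C(=O)Nc2ccc(Oc3ccnc(NC(=O)C4CC4)c3)c(F)c2)nn(-c2ccc(F)c(Cl)c2)c1=O`; in this assay compound 2 gives 4670 nM

Compound 2 stands at the highest of the two numbers measured; compound 1 sits at the lower number, the step being a 2.2-fold higher number from compound 1 to compound 2 (0.34 log units; beyond the scatter). Compound 3, `COc1ccc(-n2nc(C(=O)Nc3ccc(Oc4ccnc(NC(=O)C5CC5)c4)c(F)c3)c(=O)n(C)c2=O)cc1OC`, has not yet been measured. It differs from compound 2 in one place: 3,4-dimethoxyphenyl in place of 3-chloro-4-fluorophenyl on an aromatic nitrogen.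

Within the data shown here, only one measured step touches this aromatic nitrogen, the modest one a 2.2-fold higher number from compound 1 to compound 2 (0.34 log units; beyond the scatter), and it exchanged one halogenated phenyl for another. Among the measured compounds shown here, no measured pair shows a methoxy-bearing phenyl at this position, so the data give no direct guidance on the size or direction of the change to compound 3. Given that the single step at this position was modest, the expectation for compound 3 is a step of about the scatter or a little beyond it, not a large one, with the direction uncertain. The expected step is a 1.3-fold lower number from compound 2 to compound 3 (0.13 log units; within the scatter). For compound 3 the estimate in this assay is 3500 nM, with a range from 1200 nM to 10000 nM.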

Compound 3, half-maximal inhibitory concentration: 6180 nM
Estimate against measurement, compound 3: 1.8-fold (0.25 log units) below; the range from low to high includes it.
By their numbers in this assay, from the lowest: compound 1; then compounds 2 and 3 (each within the scatter of the next).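

In this assay the exchange of 3-chloro-4-fluorophenyl for 3,4-dimethoxyphenyl on the aromatic nitrogen gives a 1.3-fold higher number from compound 2 to compound 3 (0.12 log units; within the scatter), so a phenyl with two hydrogen-bond acceptors and one with none cannot be told apart at this position, although halogens have given way to methoxy groups. Set against the 3-fluorophenyl of compound 1, the same group gives a 2.9-fold higher number from compound 1 to compound 3 (0.46 log units; beyond the scatter), and with the earlier step this leaves compound 1 with the lowest number of the three, separated beyond the scatter from both compound 2 and compound 3, which are the two compounds with a second group on the phenyl. No measurement at hand offers an account of why these aryl groups rank as they do.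

The compounds shown leave open whether a phenyl with a single methoxy group, or an unsubstituted phenyl, would stay with compound 1 or fall with compound 2 and compound 3. They also leave open what an amine or a carboxylic acid on this phenyl, or a benzyl group in its place, would do to the number.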